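The source may report more compounds than this note shows. Statements on the series, on what has been measured and on what is new or still open speak of the compounds shown alone.

Measured in a functional assay on U-87MG ATCC cells for cytotoxicity against U-87 MG (Homo sapiens), read by MTT assay, with a stated time of 72 h; a higher number here means a weaker inhibitor, a lower number a stronger inhibitor:
- compound 1 `COc1ncc(-c2ccc3nc(NC(=O)NCCN4CCCC4)nn3c2)cc1NS(=O)(=O)c1ccc(F)cc1`: 1120 nM
- compound 2 `COc1ncc(-c2ccc3nc(NC(=O)NCCN(C)C)nn3c2)cc1NS(=O)(=O)c1ccc(F)cc1`: 980 nM
- compound 3 `CCCNC(=O)Nc1nc2ccc(-c3cnc(OC)c(NS(=O)(=O)c4ccc(F)cc4)c3)cn2n1`: 420 nM

Compound 3 has the lowest number of the three, and its steps to both others lie beyond the scatter. The remaining pair differs only within the scatter: a 1.1-fold lower number from compound 1 to compound 2 (0.06 log units; within the scatter).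

Next is compound 4 `CNC(=O)Nc1nc2ccc(-c3cnc(OC)c(NS(=O)(=O)c4ccc(F)cc4)c3)cn2n1`, with hydrogen in place of ethyl on a saturated chain carbon bound to an amide-type nitrogen, which reads as propyl to methyl: hydrogen in place of ethyl on a saturated chain carbon bound to an amide-type nitrogen. Among the measured compounds shown here, no measured step makes this exact change. The closest evidence comes from two modest steps at the same chain, a 2.7-fold lower number from compound 1 to compound 3 (0.43 log units; beyond the scatter) and a 2.3-fold lower number from compound 2 to compound 3 (0.37 log units; beyond the scatter). Each puts methyl in place of a different group, so they guide only the likely size of a change here, not its direction with any certainty. With compound 3 at the low end, a small rise is the working expectation. The expected change is a 1.3-fold higher number from compound 3 to compound 4 (0.12 log units; within the scatter), and it may not clear the scatter. For compound 4, the estimate is 550 nM, with an expected range of 230 nM to 1300 nM.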

Compound 4, half-maximal inhibitory concentration: 640 nM
Compound 4: middle estimate off by 1.2-fold (0.07 log units), on the low side; the measured number falls inside the stated range.
By their numbers in this assay, from the lowest: compounds 3, 4, 2 and 1 (each within the scatter of the next, the first and the last beyond it).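

In this assay propyl to methyl at the saturated chain carbon bound to an amide-type nitrogen gives a 1.5-fold higher number from compound 3 to compound 4 (0.18 log units; within the scatter) and so does not separate the two compounds. Methyl also stays within the scatter of both amine-bearing chains, with a 1.5-fold lower number from compound 2 to compound 4 (0.19 log units; within the scatter) and a 1.8-fold lower number from compound 1 to compound 4 (0.24 log units; within the scatter) as the steps, whereas the propyl compound stood beyond the scatter of both, so only the propyl compound stands apart from the amines. Nothing at hand accounts for these numbers.

Open, as far as these compounds go, is whether a longer chain such as butyl, a branched chain such as isopropyl, or a chain ending in a hydroxyl or a carboxylic acid would stay in this narrow band. Also open, from the compounds shown here alone, is whether the small gap between propyl and the amine-bearing chains would hold on further repeats.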